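Methyl for chloro beside a methylsulfonyl group

The source may hold more compounds than are shown below. What is called first, only, known or untested is meant among the compounds shown, and "the series" means these compounds.

Measured compounds in a functional assay on cells for antagonist activity at prostaglandin D2 receptor 2 (Homo sapiens), read by flow cytometry, with a stated time of 10 min; a higher number here means a weaker inhibitor, a lower number a stronger inhibitor:
compound 1 `Cc1ccc(S(=O)(=O)N(C)C(C)C)cc1C#Cc1cc(Cl)ccc1OCC(=O)O` gives 140 nM
compound 2 `COCCNS(=O)(=O)c1ccc(C)c(C#Cc2cc(Cl)ccc2OCC(=O)O)c1` gives 88 nM
compound 3 `CS(=O)(=O)c1ccc(Cl)c(C#Cc2cc(Cl)ccc2OCC(=O)O)c1` gives 26 nM

Compound 3 gives the lowest number of the three, and the gaps to compound 2 and to compound 1 are both beyond the usual scatter, so it is the strongest inhibitor of this set. Compound 4 `Cc1ccc(S(C)(=O)=O)cc1C#Cc1cc(Cl)ccc1OCC(=O)O` is not yet measured. It differs from compound 3 in one place: methyl in place of chloro on an aromatic carbon.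

Among the measured compounds shown here, no measured step bears directly on this change. For the measured compounds named here, the only single-point step available, a 1.6-fold lower number from compound 1 to compound 2 (0.20 log units; within the scatter), concerns the substituent on the sulfonyl sulfur, not the aromatic carbon changed here, and compounds 1 and 2 differ from compound 3 in two places at once, so their values show only that the bulkier sulfonamides of compound 1 and compound 2 come with higher numbers than the methylsulfonyl compound 3. With nothing directly comparable, the author expects the step of a 1.7-fold higher number from compound 3 to compound 4 (0.24 log units; within the scatter) to be small, and if anything toward a higher number. Compound 4 is therefore estimated at 45 nM, within the range 15 nM to 130 nM.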

Compound 4, half-maximal inhibitory concentration: 64 nM
For compound 4 the middle estimate is 1.4-fold (0.15 log units) below the measured one; low and high end bracket the measured number.
By their numbers in this assay, from the lowest: compound 3; then compounds 4, 2 and 1 (each within the scatter of the next, the first and the last beyond it).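

In this assay, among the compounds shown here, this is the first direct reading of the aromatic carbon para to the methylsulfonyl group: methyl in place of chloro there gives a 2.5-fold higher number from compound 3 to compound 4 (0.39 log units; beyond the scatter), so with the methylsulfonyl group held fixed, the chloro compound gives the lower number. With methyl held on that carbon, the substituent on the sulfonyl sulfur can also be read: methyl in place of isopropyl(methyl)amino gives a 2.2-fold lower number from compound 1 to compound 4 (0.34 log units; beyond the scatter), whereas methyl in place of (2-methoxyethyl)amino gives a 1.4-fold lower number from compound 2 to compound 4 (0.14 log units; within the scatter). Nothing given here explains the difference between chloro and methyl at this position.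

The compounds shown leave open how fluoro, methoxy or a nitrile on this aromatic carbon would compare with chloro. They also leave open whether the step from chloro to methyl holds with isopropyl(methyl)amino or (2-methoxyethyl)amino on the sulfonyl sulfur.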